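The source may report more compounds than this note shows. Statements on the series, on what has been measured and on what is new or still open speak of the compounds shown alone.

Measured compounds:
Compound 1 `O=S(=O)(c1ccc(F)cc1)c1cnc2cc(F)ccc2c1-c1ccc(F)cc1`: 1.34 mL/min
Compound 2 `O=S(=O)(c1ccc(F)cc1)c1cnc2cc(F)ccc2c1-c1ccc(Cl)cc1`: 1.23 mL/min
Compound 3 `O=S(=O)(c1ccc(F)cc1)c1cnc2cc(F)ccc2c1-c1cccc(F)c1`: 0.95 mL/min

In an ADME assay on microsomes from liver (Homo sapiens) for metabolic stability, tested at 2.5 uM (on this read-out lower numbers stand for slow clearance and higher numbers for fast clearance), compound 1 gives 1.34 mL/min, and the other two compounds sit within the scatter of it: a 1.1-fold lower number from compound 1 to compound 2 (0.04 log units; within the scatter), and a 1.4-fold lower number from compound 1 to compound 3 (0.15 log units; within the scatter). Compound 4 `COc1ccc(S(=O)(=O)c2cnc3cc(F)ccc3c2-c2ccc(F)cc2)cc1` differs from compound 1 by methoxy in place of fluoro on an aromatic carbon. Neither measured step touches this part of the shared core; both change a different ring and stay within the scatter. Among the compounds with values here, no measured step therefore bears directly on the change to compound 4, and the step expected in this assay is a 1.1-fold higher number from compound 1 to compound 4 (0.05 log units; within the scatter), no larger than the scatter. Compound 4 is estimated at 1.5 mL/min, with a range from 0.7 mL/min to 3.2 mL/min.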

Compound 4, intrinsic clearance in a liver preparation (reported as CLH), per the amount of preparation that the assay uses: 1.71 mL/min
The estimate for compound 4 lay 1.1-fold (0.06 log units) below the measured number, and the stated range covers the measured number.
By their numbers in this assay, from the lowest: compounds 3, 2, 1 and 4 (each within the scatter of the next).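

In this assay methoxy in place of fluoro gives a 1.3-fold higher number from compound 1 to compound 4 (0.11 log units; within the scatter) and so makes no clear difference. This is the first change shown on this ring, at the carbon para to a large group, and it shows that a fluoro here can give way to the larger methoxy without a clear shift in clearance. No measurement shown accounts for this result. With only these two groups shown at this position, it remains open whether an amine, a carboxylic acid or a longer chain would move clearance beyond the scatter.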